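The source may hold more compounds than are shown below. What is called first, only, known or untested is meant among the compounds shown, and "the series" means these compounds.

Compound 3 `COc1ccc(-c2c(Br)c3cc(C#N)c(C#N)cc3n2O)cc1` holds the second highest of three numbers in an assay on isolated protein for inhibition of Amine oxidase [flavin-containing] B (Homo sapiens), read by fluorescence (a higher number here means a weaker inhibitor, a lower number a stronger inhibitor), giving 1520 nM. Compound 1 `N#Cc1ccc(OC/C=C/c2ccccc2)cc1C#N` gives 642 nM in this assay, and compound 2 `N#Cc1cc2c(Br)c(-c3ccccc3)n(O)c2cc1C#N` gives 11900 nM. For the measured compounds named here, the only single-point step among the measured compounds, a 7.8-fold lower number from compound 2 to compound 3 (0.89 log units; beyond the scatter), touches a different part of the molecule. Compound 4 `COc1ccc(-c2c(Br)c3cc(C#N)c(C#N)cc3n2OC)cc1` differs from compound 3 by methyl in place of hydrogen on an oxygen on an aromatic ring. Going by the values given here, no measured step bears on this particular change, so neither its size nor its direction can be read from the known pairs, and a step that stays within the scatter is the plainest expectation. The expected step in this assay is a 1.3-fold higher number from compound 3 to compound 4 (0.12 log units; within the scatter). Compound 4 is therefore estimated at 2000 nM in this assay, with a range from 500 nM to 8000 nM.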

Compound 4, half-maximal inhibitory concentration: > 100000 nM
Compound 4: no number, only a limit (the forecaster's own chance of this, stated with the estimate: 5%); middle value at least 50-fold (1.69 log units) from the limit.
By their numbers in this assay, from the lowest: compound 1; then compound 3; then compound 2. At a limit, above all of these: compound 4.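

Changing hydroxy to methoxy on this oxygen gives an at least 65-fold higher number from compound 3 to compound 4 (1.81 log units; beyond the scatter) in this assay, the largest step among the compounds shown and the first to touch this position. Compound 4 gives no number, only a limit of the assay: the limit of > 100000 nM in this assay, at which 1 of the 4 values shown sits.

A single methyl on this oxygen is thus enough to carry a measurable inhibitor to that limit. Still open, on these data alone, is whether a longer chain such as ethyl, or an acetyl, on this oxygen would also reach the limit. Also open, as far as these compounds go, is how the compound would read with plain hydrogen in place of the hydroxy.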